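A Sulfonyl Substituent Swap and Its Expected Outcome

This account rests on a few compounds, and the source may have more. Where it says the series, first, only, none or still open, it means among the compounds named here.

Measured so far:
Compound 1, `Cc1ccsc1/C=C(/SCc1ccc(F)cc1)C(=O)c1ccc(Br)cc1`, gives 50000 nM
Compound 2, `COc1cc(OC)c(/C=C(\C(=O)c2ccc(Cl)cc2)S(=O)(=O)Cc2ccc(F)cc2)c(OC)c1`, gives 25000 nM

Both numbers come from a functional assay on DU-145 cells (Homo sapiens) for inhibition, read by trypan blue exclusion, with a stated time of 96 h; on this read-out lower numbers stand for stronger inhibition of growth and higher numbers for weaker inhibition of growth. Compound 2 and compound 1 sit close to each other: the gap between them lies within the usual scatter of repeated runs, so the two cannot be told apart on these numbers, and neither compound can be called the more active one. Compound 2 is the starting point for the next step.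

Compound 3, `COc1cc(OC)c(/C=C(\C(=O)c2ccc(Cl)cc2)S(=O)(=O)c2ccc(C)cc2)c(OC)c1`, has not yet been measured. It differs from compound 2 in one place: 4-methylphenyl in place of 4-fluorobenzyl on a sulfonyl sulfur. Going by the values given here, no measured pair shows a step of this kind, so there is no basis for expecting a shift in either direction. The expectation is therefore a step from compound 2 to compound 3 of about no change at the digits printed from compound 2 to compound 3 (within the scatter) in this assay, which is within the scatter. Compound 3 is expected to give about 25000 nM, with a likely range from 8000 nM to 80000 nM.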

Compound 3, concentration for 50% growth inhibition: 25000 nM
Beside the measured number, compound 3's estimate shows no gap at the digits printed, and the stated range covers the measured number.
By their numbers in this assay, from the lowest: compounds 2, 3 and 1 (each within the scatter of the next).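

In this assay, going by these compounds alone, replacing 4-fluorobenzyl with 4-methylphenyl on a sulfonyl sulfur gives a first direct reading of a change at this position: the step is no change at the digits printed from compound 2 to compound 3 (within the scatter). The two groups differ in their make-up, yet each carries one six-membered aromatic ring of carbon only, and for this single pair the exchange leaves the growth-inhibition number unmoved, so the position accepts either group without a visible difference on this read-out. No supporting measurement bears on why the two groups read alike, so this result describes an outcome and offers no explanation for it.

The compounds shown leave open whether a group with no aromatic ring on the sulfonyl sulfur, such as an amine or a simple ethyl chain, would read the same, and whether a carboxylic acid on the ring of the 4-methylphenyl group would shift the number in either direction. Within the data shown here, with only one step at this position, they also leave open whether the same exchange would read alike if other parts of the shared core carried different groups.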